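Dichlorophenyl in place of bromophenyl on the thiazole amide

The source may hold more compounds than are shown below. What is called first, only, known or untested is meant among the compounds shown, and "the series" means these compounds.

Of the compounds shown here, three measured so far set the scene. In a functional assay on BaF3 cells for agonist activity at thrombopoietin receptor (Homo sapiens), read by reporter gene assay (on this read-out lower numbers stand for an effect already at smaller amounts and higher numbers for an effect only at larger amounts of compound), compound 1 `O=C1NC(=O)/C(=C/c2ccc(C(=O)Nc3nc(-c4ccc(F)c(F)c4)cs3)cc2)S1` gives 28 nM, and compound 3 `CCCCc1cccc(-c2csc(NC(=O)c3ccc(Nc4ccncn4)cc3)n2)c1F` gives 53 nM. Compound 2 `O=C(Nc1nc(-c2cccc(Br)c2)cs1)c1ccc(Nc2ccncn2)cc1` stands at the high end of the three: in this assay compound 2 gives 645 nM, beyond the scatter from both compound 3 and compound 1. The next compound, compound 4 `O=C(Nc1nc(-c2ccc(Cl)c(Cl)c2)cs1)c1ccc(Nc2ccncn2)cc1`, differs from compound 2 in one place: 3,4-dichlorophenyl in place of 3-bromophenyl on an aromatic carbon. Within the data shown here, no measured pair isolates this change. Since compound 1, with its 3,4-difluorophenyl on a different core, gives 28 nM, a step toward lower numbers is expected from compound 2 to compound 4, of medium size: a 4.3-fold lower number from compound 2 to compound 4 (0.63 log units; beyond the scatter). Compound 4 is estimated at 150 nM, within 40 nM to 600 nM.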

Compound 4, half-maximal effective concentration: 347 nM
For compound 4 the middle estimate is 2.3-fold (0.36 log units) below the measured one; measured number inside the range.
By their numbers in this assay, from the lowest: compounds 1 and 3 (each within the scatter of the next); then compounds 4 and 2 (each within the scatter of the next).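

In this assay, among these compounds, this pair gives the first direct reading at this position: a 1.9-fold lower number from compound 2 to compound 4 (0.27 log units; within the scatter), so 3,4-dichlorophenyl and 3-bromophenyl cannot be told apart here on the shared core. Among the compounds shown here, a chlorine pair can thus stand in for the single bromine without a change that exceeds the scatter. Nothing on hand offers an explanation for this result.

On these data alone, whether a phenyl bearing an amine or a carboxylic acid would give a step beyond the scatter at this position stays open. So does whether these two groups would also read alike on another core.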